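Cytotoxicity on Vero Cells: From Anilino to Benzylmethylamino

This account rests on a few compounds, and the source may have more. Where it says the series, first, only, none or still open, it means among the compounds named here.

Measured compounds:
Compound 1 `CN(Cc1ccc2c(c1)OCCO2)c1nc(=O)c2cc(C(F)(F)F)cc([N+](=O)[O-])c2o1` — 9.27 ug/mL
Compound 2 `O=c1nc(NCC2CCCCC2)oc2c([N+](=O)[O-])cc(C(F)(F)F)cc12` — 29.7 ug/mL
Compound 3 `O=c1nc(Nc2ccccc2)oc2c([N+](=O)[O-])cc(C(F)(F)F)cc12` — 37.9 ug/mL

Of the compounds shown here, three sharing a common core have been measured in an ADME assay on Vero cells (Chlorocebus sabaeus) for cytotoxicity, read by MTT assay, with a stated time of 48 h; a lower number here means a stronger inhibitor, a higher number a weaker inhibitor. Compound 3 gives the highest of the three numbers; its nearest neighbour is compound 2, which gives 29.7 ug/mL, and the gap between them, a 1.3-fold higher number from compound 2 to compound 3 (0.11 log units; within the scatter), is within the scatter. Among the measured compounds shown here, the furthest is compound 1, which gives 9.27 ug/mL, a number lower than that of compound 3 by more than the scatter allows; no single-point step connects these two, so only their two values can be set side by side.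

Compound 4 `CN(Cc1ccccc1)c1nc(=O)c2cc(C(F)(F)F)cc([N+](=O)[O-])c2o1` has not yet been measured in this assay. It differs from compound 3 in one place: benzyl(methyl)amino in place of anilino on an aromatic carbon. Of the measured steps, only the change from compound 2 to compound 3 touches the same position, and it was small. Compound 1 carries the same benzyl(methyl)amino arrangement with an added ring and gave the lowest number seen. On that basis compound 4 is expected to move toward compound 1, with a step of a 2.5-fold lower number from compound 3 to compound 4 (0.40 log units; beyond the scatter) that may just pass the scatter. Compound 4 is therefore estimated at 15 ug/mL, within a range from 6 ug/mL to 40 ug/mL.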

Compound 4, half-maximal inhibitory concentration: 3.84 ug/mL
Beside the measured number, compound 4's estimate is 3.9-fold (0.59 log units) above it; measured number below the stated range.
By their numbers in this assay, from the lowest: compound 4; then compound 1; then compounds 2 and 3 (each within the scatter of the next).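

In this assay, the carbon next to the ring nitrogen and next to the ring oxygen proves sensitive to the amino group it carries: replacing anilino with benzyl(methyl)amino gives a 9.9-fold lower number from compound 3 to compound 4 (0.99 log units; beyond the scatter), whereas the only earlier step at this place, a 1.3-fold higher number from compound 2 to compound 3 (0.11 log units; within the scatter), had shown no resolved change. The same entering group also separates compound 4 from the (cyclohexylmethyl)amino compound, with a 7.7-fold lower number from compound 2 to compound 4 (0.89 log units; beyond the scatter), so benzyl(methyl)amino stands apart from both of the other amino groups, and compound 4 has the lowest number of the set. The 2,3-dihydro-1,4-benzodioxin-6-yl group of compound 1 is not needed to reach this low range, and its replacement by phenyl gives a 2.4-fold lower number from compound 1 to compound 4 (0.38 log units; beyond the scatter), a further change beyond the scatter; nothing measured here offers an explanation for any of these steps.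

The step from anilino to benzyl(methyl)amino changes two things at once, adding a methyl on the nitrogen and a carbon between the nitrogen and the phenyl ring, and the compounds shown do not divide the change between them. A benzylamino or a methyl(phenyl)amino group at this carbon would separate the two, while a piperidine ring would show whether an open benzyl arm is required at all.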